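This account rests on a few compounds, and the source may have more. Where it says the series, first, only, none or still open, it means among the compounds named here.

Measured so far in a physicochemical assay for lipophilicity, at pH 7.4; on this read-out higher numbers stand for higher lipophilicity and lower numbers for lower lipophilicity:
- compound 1 `CNC(=O)c1cc(C(=O)N[C@H]2[C@@H]3COC[C@@H]32)cc2c1OC[C@@]2(CO)c1ccccc1` gives 2.4
- compound 2 `CNC(=O)c1cc(C(=O)N[C@H]2[C@@H]3C[C@@H](O)C[C@@H]32)cc2c1OC[C@H]2c1ccccc1` gives 2.9

Of these two numbers, compound 2 stands highest (2.9), and compound 1 lies lower, beyond the scatter. The two compounds differ in more than one place, so no single structural change can be read from their values.

Still unmeasured in this assay is compound 3 `CNC(=O)c1cc(C(=O)Nc2cnn(C)c2)cc2c1OC[C@H]2c1ccccc1`, which differs from compound 2 on an amide-type nitrogen: a group of 6 heavy atoms (4 carbon, 2 nitrogen; one five-membered aromatic ring with 2 hetero atoms) in place of a group of 7 heavy atoms (6 carbon, 1 oxygen; one three-membered non-aromatic ring of carbon only, one five-membered non-aromatic ring of carbon only), on an amide-type nitrogen. The entering group is 1-methyl-1H-pyrazol-4-yl. Among the measured compounds shown here, no measured pair isolates this exchange, or any other single exchange, so the expectation has little direct support. For the measured compounds named here, the only anchor is compound 2 (2.9), which shares the rest of the structure with compound 3.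

In this assay a small upward step is expected, not beyond the scatter. The estimated change is a number 0.20 log units higher from compound 2 to compound 3 (within the scatter) and is expected to stay within that scatter. For compound 3 the expected value is 3.1, with an estimated range (2.6 to 3.6).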

Compound 3, distribution coefficient: 3.5
The estimate for compound 3 lay 0.40 log units below the measured number; low and high end bracket the measured number.
By their numbers in this assay, from the lowest: compound 1; then compound 2; then compound 3.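

Notes on the amide-type nitrogen whose other neighbour is the carbonyl carbon: this is the first single exchange in the series that can be read on its own, and in this assay it gives a number 0.60 log units higher from compound 2 to compound 3 (beyond the scatter) for 1-methyl-1H-pyrazol-4-yl in place of the group with a three-membered and a five-membered non-aromatic ring of carbon only. The number at this position therefore moves with the group on this nitrogen while the rest of the structure stays the same, which the earlier pair, differing in more than one place, could not show. The exchange alters the ring type, the hetero atoms and the hydrogen-bond counts all at once (the group leaving has 1 donor and 1 acceptor, the entering group 0 donors and 2 acceptors), and no measurement at hand accounts for the step.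

Still open, going by these compounds, is which of these differences carries the step, and whether the same step would appear on the core of compound 1. A phenyl group, a 1H-pyrazol-4-yl without the methyl, or an aminocyclohexyl group on the same nitrogen would begin to separate these differences.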